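A few compounds are considered here, and "the series" means these few. Any claim that something is new, unique, unknown or untested is made for them only; others in the source may bear on it.

In a functional assay on Hs-578T cells (Homo sapiens) for inhibition, read by sulforhodamine B assay, with a stated time of 48 h, tested at 10 uM (a higher number here means more inhibition of growth at the concentration tested, a lower number less inhibition of growth), compound 1 `CC(=O)c1ccc(NC(=O)Cn2nc(-c3ccc(Cl)cc3)nc2N)cc1` gives 6.29%, while compound 2 `COc1ccc(-c2nc3sc(-c4ccccc4)cn3n2)cc1` gives 40%, the higher of the two numbers by a gap beyond the usual scatter. Compound 3 `COc1ccc(-c2nc3sc(-c4ccc(Cl)cc4)cn3n2)cc1` differs from compound 2 in one place: chloro in place of hydrogen on an aromatic carbon, a chloro in place of hydrogen on an aromatic carbon, which turns phenyl into 4-chlorophenyl. Going by the values given here, no two measured compounds differ in a single place, so this change remains untested here. A small rise that stays within the scatter is expected, with an estimated a number 5 percentage points higher from compound 2 to compound 3 (within the scatter). Compound 3 is estimated to give 45%, within a range of 25% to 65%.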

Compound 3, percent growth inhibition at one concentration: 73%
Compound 3: middle estimate off by 28 percentage points, on the low side; measured number above the stated range.
By their numbers in this assay, from the lowest: compound 1; then compound 2; then compound 3.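

Going by these compounds alone, the change from phenyl to 4-chlorophenyl gives a number 33 percentage points higher from compound 2 to compound 3 (beyond the scatter) in this assay and is the only single-place comparison available. It shows that this position, para to a large group on the six-membered aromatic ring, is not indifferent to substitution: one added chlorine atom is enough to change growth inhibition by more than the usual scatter. From the compounds shown here alone, whether a fluoro group, a methoxy group or an amine at the same position would also raise inhibition remains open. Nothing measured here gives a reason for the rise.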